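The compounds below may be only part of what the source reports. "The series", "measured", "known", "first", "only" and "open" are said of these compounds alone.

Working notes on the series. Within the data shown here, in a functional assay on SF-295 cells (Homo sapiens) (on this read-out lower numbers stand for stronger inhibition of growth and higher numbers for weaker inhibition of growth), compound 2 `COc1ccc(-c2cc(O)c3cc(C)cnc3n2)cc1` gives 5250 nM, the higher of the only two numbers available, while compound 1 `Cc1cnc2nc(-c3ccc(Cl)cc3)cc(O)c2c1` gives 2400 nM. The next change leads from compound 2 to compound 3 `Cc1cnc2nc(-c3ccc(F)cc3)cc(O)c2c1`: fluoro in place of methoxy on an aromatic carbon, para to a large group (fluoro in place of methoxy on an aromatic carbon). Among the measured compounds shown here, only one measured step bears on this change: a 2.2-fold higher number from compound 1 to compound 2 (0.34 log units; beyond the scatter), a modest step for methoxy in place of chloro on an aromatic carbon. For the measured compounds named here, compound 3 also loses the methoxy, but no measurement yet compares fluoro with chloro, so that step is only a rough guide. Given the step to compound 2, a modest move toward a lower number is expected in this assay, no larger than that step and possibly within the scatter. The expected step is a 1.6-fold lower number from compound 2 to compound 3 (0.22 log units; within the scatter). For compound 3 the estimated value is 3200 nM, with an expected range of 1400 nM to 7500 nM.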

Compound 3, concentration for 50% growth inhibition: 29500 nM
Beside the measured number, compound 3's estimate is 9.2-fold (0.96 log units) below it; measured number outside the range, above it.
By their numbers in this assay, from the lowest: compound 1; then compound 2; then compound 3.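

Among these compounds, this position proves far more sensitive in this assay than the one earlier step suggested: the single change to fluoro gives a 5.6-fold higher number from compound 2 to compound 3 (0.75 log units; beyond the scatter) and, measured against chloro, a 12-fold higher number from compound 1 to compound 3 (1.09 log units; beyond the scatter) on the same core. Both steps exceed the earlier one for methoxy in place of chloro (a 2.2-fold higher number from compound 1 to compound 2 (0.34 log units; beyond the scatter)), so chloro and methoxy lie much closer to each other than either does to fluoro, and compound 3 is the weakest of the three, with both of its steps beyond the scatter. Nothing at hand explains why fluoro departs so sharply from the other two groups on this aromatic carbon.

With only three groups at this place, the compounds shown cannot tell whether fluoro is a lone exception or whether other groups, such as an amine, a nitrile or a trifluoromethyl, would also fall far from chloro and methoxy. On these data alone, it also stays open whether a plain hydrogen here would sit nearer to chloro or to fluoro, and whether the same order holds when the methyl or the hydroxyl on the shared core is changed.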